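The source may hold more compounds than are shown below. What is called first, only, known or untested is meant among the compounds shown, and "the series" means these compounds.

Measured so far in a functional assay on HL-60 cells (Homo sapiens) for cytotoxicity, read by luminescence and CellTiter-Glo, with a stated time of 3 days; a higher number here means a weaker inhibitor, a lower number a stronger inhibitor:

- compound 1 `N#Cc1cc(Cl)ccc1NC(=O)c1ccc2cccnc2c1O`: 790 nM
- compound 2 `O=C(Nc1cc(Cl)cc(Cl)c1)c1cc(F)ccc1O`: 600 nM
- compound 3 `Cc1cc(C#N)ccc1NC(=O)c1ccc2cccnc2c1O`: 710 nM

In this assay, compound 3 gives 710 nM. That value lies within the scatter of compound 1 at 790 nM and also within the scatter of compound 2 at 600 nM. On these numbers, compound 3 cannot be separated from either of them.

The next compound, compound 4 `N#Cc1ccc(NC(=O)c2ccc3cccnc3c2O)c(C#N)c1`, keeps the core of compound 3 and has cyano in place of methyl on an aromatic carbon. The new group stands ortho to a large group and meta to a cyano group.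

Within the data shown here, no two measured compounds differ in one place only, so no measured step shows what this exchange does. The nearest guide, which shares the core of compound 3 and also carries cyano, is compound 1 at 790 nM. This comparison is loose, and it points to no step beyond the scatter in this assay and to no firm direction. The expected step is a 1.1-fold higher number from compound 3 to compound 4 (0.05 log units; within the scatter), which would stay within the scatter. For compound 4, the estimated value is 800 nM, with an expected range from 300 nM to 2000 nM.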

Compound 4, half-maximal inhibitory concentration: 890 nM
Compound 4: middle estimate off by 1.1-fold (0.05 log units), on the low side; measured number inside the range.
By their numbers in this assay, from the lowest: compounds 2, 3, 1 and 4 (each within the scatter of the next).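

The exchange of methyl for cyano on an aromatic carbon, ortho to a large group and meta to a cyano group, gives a 1.3-fold higher number from compound 3 to compound 4 (0.10 log units; within the scatter) in this assay. Among these compounds, this is the first one-place comparison at this position, and on this evidence methyl and cyano there cannot be told apart, even though cyano brings one more heavy atom and a hydrogen-bond acceptor. Cyano in place of chloro on an aromatic carbon gives a 1.1-fold higher number from compound 1 to compound 4 (0.05 log units; within the scatter), so this second exchange cannot be separated from the scatter either, and nothing at hand accounts for either result.

The compounds shown leave open whether a different kind of group on this carbon, such as an amine, a carboxylic acid or a longer chain, would produce a step beyond the scatter. They also leave open what a methoxy group would do in place of the cyano group that compound 3 and compound 4 share, since neither of the two steps shows any group moving the number clearly in either direction.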